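From 2,3-Dimethoxyphenyl to 2,4-Dimethoxyphenyl at the Assay Limit

This account rests on a few compounds, and the source may have more. Where it says the series, first, only, none or still open, it means among the compounds named here.

In a functional assay on K562 cells (Homo sapiens) for antiproliferative activity, with a stated time of 72 h (a higher number here means a weaker inhibitor, a lower number a stronger inhibitor), compound 1 `OC[C@H]1O[C@@H](n2cnc3c(NCc4ccc(Br)cc4)ncnc32)[C@H](O)[C@@H]1O` with its 4-bromophenyl group gives 68200 nM and is the only one of the three measured compounds to return a number. Compound 2 `Cc1cccc(CNc2ncnc3c2ncn3[C@@H]2O[C@H](CO)[C@@H](O)[C@H]2O)c1` with 3-methylphenyl in that place gives only a limit (> 166000 nM) and no number. Compound 3 `COc1cccc(CNc2ncnc3c2ncn3[C@@H]2O[C@H](CO)[C@@H](O)[C@H]2O)c1OC` with 2,3-dimethoxyphenyl there also gives only a limit (> 166000 nM) and no number. Compound 3 therefore stands at the limit of > 166000 nM in this assay, at which 2 of the 3 values shown sit, and has no value of its own.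

Compound 4 `COc1ccc(CNc2ncnc3c2ncn3[C@@H]2O[C@H](CO)[C@@H](O)[C@H]2O)c(OC)c1` has the same atoms joined differently (2,4-dimethoxyphenyl in place of 2,3-dimethoxyphenyl on a saturated chain carbon bound to a nitrogen on an aromatic ring) with 2,4-dimethoxyphenyl in place of 2,3-dimethoxyphenyl on a saturated chain carbon bound to a nitrogen on an aromatic ring. Leaving 4-bromophenyl gave an at least 2.4-fold higher number from compound 1 to compound 2 (0.38 log units; beyond the scatter) and gave an at least 2.4-fold higher number from compound 1 to compound 3 (0.38 log units; beyond the scatter) in the same direction. Between the other two there is a step that the two limits leave unreadable from compound 2 to compound 3 and no measured step compares two dimethoxyphenyl groups directly. Compound 4 keeps a dimethoxyphenyl group like compound 3 at > 166000 nM and lacks the 4-bromophenyl of compound 1, so in this assay it is expected to stay in that region, with no step beyond the scatter. The expected change is a step that the limit leaves unreadable from compound 3 to compound 4 and it is read against a limit. For compound 4 the estimate is 170000 nM with an expected range from 90000 nM to 340000 nM and a report as a limit alone is the likeliest outcome.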

Compound 4, half-maximal inhibitory concentration: > 166000 nM
Compound 4: a limit, no number (the forecaster's own chance of this, stated with the estimate: 75%); the middle value lies beyond the limit too.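

Exchanging 2,3-dimethoxyphenyl for 2,4-dimethoxyphenyl on a saturated chain carbon bound to a nitrogen on an aromatic ring does not bring a number back in this assay: compound 4 gives > 166000 nM, which is a limit of the assay and not a number. Leaving 4-bromophenyl gives an at least 2.4-fold higher number from compound 1 to compound 4 (0.38 log units; beyond the scatter), so three different groups in that place, 3-methylphenyl and both dimethoxyphenyl groups, now go the same way, and a second arrangement of the two methoxy groups joins the first. The steps among compound 2, compound 3 and compound 4 cannot be read, so neither the two dimethoxyphenyl groups nor 3-methylphenyl can be put in any order, and the series has one number with everything else at a single limit: the limit of > 166000 nM in this assay, at which 3 of the 4 values shown sit.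

On these data alone, how far compound 2, compound 3 and compound 4 lie beyond that limit remains open. Also open, as far as these compounds go, is whether the number of compound 1 is tied to bromine, or whether a 4-chlorophenyl or 4-methylphenyl group in the same place would also return a number.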